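The compounds below may be only part of what the source reports. "The series", "measured", "known", "first", "only" and "open" are said of these compounds alone.

Measured so far in an ADME assay on MT4 cells (Homo sapiens) for cytotoxicity, read by MTT assay; a lower number here means that less compound is tolerated, a higher number that more compound is tolerated:

- compound 1 `CCOC(=O)/C(O)=C/C(=O)c1cn(Cc2ccc(F)cc2)c2ccc(OC)c(OC)c12`: 111000 nM
- compound 2 `COc1cccc2c1c(C(=O)/C=C(\O)C(=O)O)cn2Cc1ccc(F)cc1`: 41100 nM

Of these two numbers, compound 2 has the lower one, so the cells tolerate less of it. Compound 1 stands higher by more than the usual scatter of repeated measurements.

Compound 3 `COc1ccc2c(c(C(=O)/C=C(\O)C(=O)O)cn2Cc2ccc(F)cc2)c1OC` has not yet been measured. It is compound 2 with a single change: methoxy in place of hydrogen on an aromatic carbon. The new group sits ortho to a methoxy group, on a six-membered aromatic ring of carbon only.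

Among the measured compounds shown here, no measured pair shows what this kind of change does, so any expectation here is rough. For the measured compounds named here, the only other guide is the number for compound 1, 111000 nM. In this assay a small upward move is expected, probably none beyond the scatter. The estimated change is a 1.3-fold higher number from compound 2 to compound 3 (0.13 log units; within the scatter). For compound 3 the estimated half-maximal cytotoxic concentration is 55000 nM, with an expected range from 20000 nM to 130000 nM.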

Compound 3, half-maximal cytotoxic concentration: 126000 nM
Estimate against measurement, compound 3: 2.3-fold (0.36 log units) below, and the stated range covers the measured number.
By their numbers in this assay, from the lowest: compound 2; then compounds 1 and 3 (each within the scatter of the next).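

In this assay, adding a methoxy group to the aromatic carbon ortho to the existing methoxy group gives a 3.1-fold higher number from compound 2 to compound 3 (0.49 log units; beyond the scatter) and so places compound 3 on the better-tolerated side of compound 2 by a modest step. Among the compounds shown here, this is the first direct reading of this change at this position, as the earlier compounds differed from each other in more than one place. Replacing ethyl with hydrogen on the ester oxygen gives a 1.1-fold higher number from compound 1 to compound 3 (0.06 log units; within the scatter) in this assay and leaves no order between the two compounds, while no further kind of measurement bears on either step.

A single step at a single position cannot show whether the higher number belongs to methoxy itself or would also come with another group there, such as ethoxy, a hydroxyl group, a chlorine atom or an amine. As far as these compounds go, it also remains open whether the same methoxy group would give a similar step on a different carbon of this ring, or on a compound with a different group in place of the fluorobenzyl group.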